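The compounds below may be only part of what the source reports. "The series", "measured", "known", "first", "only" and "open" are said of these compounds alone.

Going by the values given here, compound 2 `N#CC1=C(N)Oc2c(c3nc4ccccc4nc3c3ccccc23)C12C(=O)N(Cc1cnnn1-c1cccc(S(N)(=O)=O)c1)c1ccccc12` is the only compound in this set with a number in an ADME assay on HUVEC cells (Homo sapiens) for antiproliferative activity, read by MTT assay, with a stated time of 48 h; a higher number here means a weaker inhibitor, a lower number a stronger inhibitor: compound 2 gives 38600 nM. Compound 1 `N#CC1=C(N)Oc2c(c3nc4ccccc4nc3c3ccccc23)C12C(=O)N(Cc1cnnn1-c1ccc(N)cc1)c1ccccc12` is the other measured compound, and in this assay compound 1 gives only a limit, > 50000 nM. Among the compounds with values here, the single measured step, an at least 1.2-fold lower number from compound 1 to compound 2 (0.11 log units; that floor lies within the scatter), therefore rests on one side on a limit; the relevant point is the limit of > 50000 nM in this assay, at which 1 of the 2 values shown sits, and that step's floor is within the usual scatter, so it shows no clear change.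

Compound 3 `Cc1ccc(C)c(-n2nncc2CN2C(=O)C3(C(C#N)=C(N)Oc4c3c3nc5ccccc5nc3c3ccccc43)c3ccccc32)c1` is not yet measured. It differs from compound 2 as follows: 2,5-dimethylphenyl in place of 3-sulfamoylphenyl on an aromatic nitrogen. Within the data shown here, the one measured step also exchanged one substituted phenyl for another on the same aromatic nitrogen, and it produced nothing beyond the scatter. Among the measured compounds shown here, no measured step involves a phenyl carrying two methyl groups and no donor or acceptor, so there is no basis for expecting a shift in either direction. The expected step is thus a 1.0-fold higher number from compound 2 to compound 3 (0.02 log units; within the scatter), no change beyond the scatter. For compound 3 in this assay the estimate is 40000 nM, with a range from 12000 nM to 130000 nM.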

Compound 3, half-maximal inhibitory concentration: > 50000 nM
Compound 3: a limit, no number; the forecaster's own chance of this, stated with the estimate: 45%; middle value at least 1.2-fold (0.09 log units) away from the limit.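

The exchange of 3-sulfamoylphenyl for 2,5-dimethylphenyl on the aromatic nitrogen gives an at least 1.2-fold higher number from compound 2 to compound 3 (0.11 log units; that floor lies within the scatter), so this second exchange of one substituted phenyl for another also shows no clear change in this assay. It adds a phenyl with two methyl groups and no hydrogen-bond donor or acceptor at this position, and there compound 3 gives only a limit, > 50000 nM. The step between compound 1 and compound 3 cannot be read, and the limit now holds most of the set: the limit of > 50000 nM in this assay, at which 2 of the 3 values shown sit.

Going by these compounds, whether a carboxylic acid or a methoxy group on this phenyl, or a plain unsubstituted phenyl, would give a number clearly apart from that of compound 2 remains open. With a single number among these compounds, and with all of them differing only in the group on this aromatic nitrogen, the set also leaves open whether any group at this position, or any change elsewhere on the shared core, moves the read-out beyond the scatter.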